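Swapping the aryl group on the amide of compound 2

The source may hold more compounds than are shown below. What is called first, only, known or untested is meant among the compounds shown, and "the series" means these compounds.

Measured compounds:
- compound 1, `COc1cc2c(Nc3nc4ccc(C(=O)Nc5c(C)cc(C)cc5C)cc4s3)ncnc2cc1OCCCN1CCCC1`: 4600 nM
- compound 2, `COc1cc2c(Nc3nc4ccc(C(=O)Nc5c(C)cc(C)cc5C)cc4s3)ncnc2cc1OCCCN1CCCCC1C`: 3600 nM
- compound 3, `COc1cc2c(Nc3nc4ccc(C(=O)Nc5c(C)cc(C)cc5C)cc4s3)ncnc2cc1OCCCN1CCC(C)CC1`: 5600 nM

In a functional assay on U-937 cells (Homo sapiens) for cytotoxicity, read by WST assay, with a stated time of 72 h (on this read-out higher numbers stand for weaker inhibition and lower numbers for stronger inhibition), compound 2 gives the lowest number of the three, but its gaps to the others, a 1.3-fold lower number from compound 1 to compound 2 (0.11 log units; within the scatter) and a 1.6-fold higher number from compound 2 to compound 3 (0.19 log units; within the scatter), both lie within the scatter, so the three are indistinguishable. Compound 4, `COc1cc2c(Nc3nc4ccc(C(=O)Nc5c(C)cccc5Cl)cc4s3)ncnc2cc1OCCCN1CCCCC1C`, differs from compound 2 at a new place: 2-chloro-6-methylphenyl in place of 2,4,6-trimethylphenyl on an amide-type nitrogen. Going by the values given here, every measured step concerns the amine at the end of the chain, not the amide aryl group, so no measured step bears on this change and its direction is unknown. The step of no change at the digits printed from compound 2 to compound 4 (within the scatter) is therefore expected to be small, and compound 4 is estimated at 3600 nM, within 1200 nM to 11000 nM.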

Compound 4, half-maximal inhibitory concentration: 7000 nM
The estimate for compound 4 lay 1.9-fold (0.29 log units) below the measured number, and the stated range covers the measured number.
By their numbers in this assay, from the lowest: compounds 2, 1, 3 and 4 (each within the scatter of the next).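

In this assay, going by these compounds alone, this is the first look at the amide aryl group, and the swap to 2-chloro-6-methylphenyl gives a 1.9-fold higher number from compound 2 to compound 4 (0.29 log units; within the scatter). So, like the amine changes at the chain end, this change on the amide-type nitrogen cannot be told apart from no change on this read-out. No outside information on the cause of this step is available.

Still open, as far as these compounds go, is whether an unsubstituted phenyl or a pyridyl group on the amide would stand clear of the scatter. Also open, from the compounds shown here alone, is whether 2-chloro-6-methylphenyl behaves alike when paired with the pyrrolidin-1-yl chain end of compound 1.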